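Capping the hydroxy group of compound 2 as methoxy

A few compounds are considered here, and "the series" means these few. Any claim that something is new, unique, unknown or untested is made for them only; others in the source may bear on it.

In a functional assay on OVCAR-3 cells (Homo sapiens) for inhibition, read by MTT assay, with a stated time of 24 h (a higher number here means a weaker inhibitor, a lower number a stronger inhibitor), compound 1 `CC1(C)[C@H]2CC[C@]1(C)N(Cc1cn(-c3ccccc3O)nn1)C(=O)C2` gives 90 nM and compound 2 `CC1(C)[C@H]2CC[C@]1(C)N(Cc1cn(-c3cccc(O)c3)nn1)C(=O)C2` gives 370 nM. Compound 2 therefore holds the higher of the two numbers and is the weaker inhibitor of the pair. The next structure is compound 3 `COc1cccc(-n2cc(CN3C(=O)C[C@@H]4CC[C@@]3(C)C4(C)C)nn2)c1`, which differs from compound 2 by methyl in place of hydrogen on an oxygen on an aromatic ring, which turns 3-hydroxyphenyl into 3-methoxyphenyl.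

Among the measured compounds shown here, only one measured step is available, a 4.1-fold higher number from compound 1 to compound 2 (0.61 log units; beyond the scatter). It is a modest change beyond the scatter, but it exchanges 2-hydroxyphenyl for 3-hydroxyphenyl and does not touch the hydrogen on the oxygen. For the measured compounds named here, no measured compound carries a methoxy group, so the data give no direction for this change. The expectation in this assay therefore stays close to compound 2 at 370 nM, with no shift beyond the scatter, and the range is kept wide. The expected change is a 1.1-fold higher number from compound 2 to compound 3 (0.03 log units; within the scatter). For compound 3 the estimated value is 400 nM, within an expected range of 130 nM to 1200 nM.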

Compound 3, half-maximal inhibitory concentration: 280 nM
For compound 3 the middle estimate is 1.4-fold (0.15 log units) above the measured one; low and high end bracket the measured number.
By their numbers in this assay, from the lowest: compound 1; then compounds 3 and 2 (each within the scatter of the next).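

In this assay, methyl in place of hydrogen on the oxygen gives a 1.3-fold lower number from compound 2 to compound 3 (0.12 log units; within the scatter) and so turns 3-hydroxyphenyl into 3-methoxyphenyl without a change that can be told apart from the scatter; at this position the hydrogen on the oxygen is therefore not required for the number seen in this cell assay. The difference from 2-hydroxyphenyl survives the capping, with a 3.1-fold higher number from compound 1 to compound 3 (0.49 log units; beyond the scatter) and thus beyond the scatter, so among these three compounds compound 1 alone stands apart, and both groups in the other position share its disadvantage whether or not they carry that hydrogen. Nothing available explains either result, whether for the placement of the hydroxy group or for the tolerance of methyl on the oxygen.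

Still open, going by these compounds, is whether the same capping of the hydroxy group of compound 1 would keep its number or lose it, which would show if the hydrogen on the oxygen matters there. Also open, on these data alone, is how an amine or a longer chain such as ethoxy in place of methoxy would read in this assay.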